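The source may report more compounds than this note shows. Statements on the series, on what has been measured and on what is new or still open speak of the compounds shown alone.

Measured so far:
Compound 1, `CCCCNc1nc2c(SCc3ccccc3)ncnc2n1C1O[C@H](CO)[C@@H](O)[C@H]1O`, gives 5.4 nM in an assay on cell membranes for binding affinity to Equilibrative nucleoside transporter 1 (Homo sapiens); on this read-out higher numbers stand for weaker inhibition and lower numbers for stronger inhibition.
Compound 2, `CCCCCNc1nc2c(SCc3ccccc3)ncnc2n1C1O[C@H](CO)[C@@H](O)[C@H]1O`, gives 2.3 nM in this assay.

Compound 2 therefore has the lower of the two numbers shown, and the step from compound 1 to compound 2, a 2.3-fold lower number from compound 1 to compound 2 (0.37 log units; beyond the scatter), is beyond the usual scatter, so compound 2 counts as the stronger of the two on this read-out.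

Compound 3, `CCC(C)CNc1nc2c(SCc3ccccc3)ncnc2n1C1O[C@H](CO)[C@@H](O)[C@H]1O`, has not yet been measured. It differs from compound 2 by sec-butyl in place of butyl on a saturated chain carbon bound to a nitrogen on an aromatic ring. In other words, the pentyl chain of compound 2 is kept in its atom count but folded into a branched shape.

Going by the values given here, the one measured step, a 2.3-fold lower number from compound 1 to compound 2 (0.37 log units; beyond the scatter), concerns chain length, not branching, so it bears on this change only loosely: it shows that adding a carbon to the chain helped modestly, but nothing shows how a branch at the carbon next to the ring nitrogen behaves. Among the compounds with values here, with no direct precedent, the expected change from compound 2 to compound 3 is a 1.5-fold higher number from compound 2 to compound 3 (0.18 log units; within the scatter), that is, within the scatter or a small rise in the number. Compound 3 is therefore estimated at 3.5 nM, with a likely range from 1.3 nM to 9 nM.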

Compound 3, inhibition constant: 3.6 nM
Compound 3: the middle estimate sits 1.0-fold (0.01 log units) below what was measured; measured number inside the range.
By their numbers in this assay, from the lowest: compounds 2, 3 and 1 (each within the scatter of the next, the first and the last beyond it).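

Folding the pentyl chain of compound 2 into the 2-methylbutyl chain of compound 3 keeps the carbon count and gives a 1.6-fold higher number from compound 2 to compound 3 (0.19 log units; within the scatter) in this assay, so at this position, on a saturated chain carbon bound to a nitrogen on an aromatic ring, this branched chain cannot be told apart from the straight one. Compound 3 can also be read as compound 1 with a methyl in place of hydrogen on a saturated chain carbon bound to two saturated chain carbons, which gives a 1.5-fold lower number from compound 1 to compound 3 (0.18 log units; within the scatter), so this added carbon, placed as a branch, does not produce a change beyond the scatter, whereas the added carbon at the end of the chain gave a 2.3-fold lower number from compound 1 to compound 2 (0.37 log units; beyond the scatter). Nothing measured here offers a reason for this difference between the two added carbons.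

The compounds shown leave open whether a longer chain, such as hexyl, or a branch of a different shape, such as 3-methylbutyl, would stay in this range of numbers. They also leave open what a ring, such as cyclopentyl, or a chain ending in an amine or a carboxylic acid would do at this position.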